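Nitro to hydroxy on the best compound so far

The source may hold more compounds than are shown below. What is called first, only, known or untested is meant among the compounds shown, and "the series" means these compounds.

In a functional assay on MDA-MB-468 cells (Homo sapiens) for antiproliferative activity, read by MTT assay, with a stated time of 72 h (a lower number here means a stronger inhibitor, a higher number a weaker inhibitor), compound 1 `COc1ccc(-n2ccnc2-c2cc(OC)c(OC)c(OC)c2)cc1[N+](=O)[O-]` gives 100 nM and holds the lowest of the three measured numbers. Compound 3 `COc1cc(-c2nccn2-c2cccc([N+](=O)[O-])c2)cc(OC)c1OC` gives 7200 nM and compound 2 `COc1cc(OC)cc(-n2ccnc2-c2cc(OC)c(OC)c(OC)c2)c1` gives 57500 nM in the same test. Compound 4 `COc1ccc(-n2ccnc2-c2cc(OC)c(OC)c(OC)c2)cc1O` differs from compound 1 by hydroxy in place of nitro on an aromatic carbon in one place: hydroxy in place of nitro on an aromatic carbon, ortho to a methoxy group. For the measured compounds named here, the only measured step, a 72-fold higher number from compound 1 to compound 3 (1.86 log units; beyond the scatter) with hydrogen in place of methoxy, is large, but it removes the methoxy group that compound 4 keeps. Going by the values given here, no measured step changes the nitro itself, so no firm direction follows. The estimated change is a 1.7-fold lower number from compound 1 to compound 4 (0.22 log units; within the scatter) in this assay and is expected to stay within the scatter. Compound 4 is estimated at 60 nM with an expected range from 10 nM to 400 nM when tested.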

Compound 4, half-maximal inhibitory concentration: 300 nM
The estimate for compound 4 lay 5.0-fold (0.70 log units) below the measured number, within the range that was stated.
By their numbers in this assay, from the lowest: compound 1; then compound 4; then compound 3; then compound 2.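

Hydroxy in place of nitro on an aromatic carbon, ortho to a methoxy group, gives the first measured change at the nitro position: a 3.0-fold higher number from compound 1 to compound 4 (0.48 log units; beyond the scatter) in this assay. For the compounds shown here, the step is modest, so at this position the nitro is not the only group compatible with antiproliferative activity, although here it gives the lower number. No available evidence accounts for this step.

Going by these compounds, whether an amine or a carboxylic acid at this position would match nitro or hydroxy remains open. Also open, on these data alone, is how removing the methoxy group would affect the hydroxy compound.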